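The compounds below may be only part of what the source reports. "The series", "measured", "known", "first", "only" and "open" are said of these compounds alone.

The measured compounds in this study:

Compound 1, `NC(=O)c1c(NC(=O)c2ccccc2Cl)sc2c1CCN(C(=S)Nc1ccccc1F)C2`, gives 12600 nM.
Compound 2, `NC(=O)c1c(NC(=O)c2ccccc2Cl)sc2c1CCN(C(=S)Nc1ccccc1Br)C2`, gives 10800 nM.
Compound 3, `NC(=O)c1c(NC(=O)c2ccccc2Br)sc2c1CCN(C(=S)Nc1ccccc1F)C2`, is reported only as a limit, > 50000 nM.

All three were tested in a functional assay on MKN-74 cells (Homo sapiens) for antiproliferative activity, with a stated time of 24 h; a lower number here means a stronger inhibitor, a higher number a weaker inhibitor. Compound 1 and compound 2 differ by bromo in place of fluoro on an aromatic carbon, and the step between them is a 1.2-fold lower number from compound 1 to compound 2 (0.07 log units; within the scatter). Compound 3 differs from compound 1 in the core: bromo in place of chloro on an aromatic carbon. That step is an at least 3.9-fold higher number from compound 1 to compound 3 (0.59 log units; beyond the scatter). For compound 3 this assay reports no number but a limit, > 50000 nM, namely (the limit of > 50000 nM in this assay, at which 1 of the 3 values shown sits).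

Compound 4, `NC(=O)c1c(NC(=O)c2ccccc2Br)sc2c1CCN(C(=S)Nc1ccccc1Br)C2`, is not yet measured. For the measured compounds named here, it differs from compound 3 by bromo in place of fluoro on an aromatic carbon, the same change as the one between compound 1 and compound 2, at the same place. Because that earlier step was a 1.2-fold lower number from compound 1 to compound 2 (0.07 log units; within the scatter), compound 4 is expected to sit close to compound 3, with a step that the limit leaves unreadable from compound 3 to compound 4. The estimate for compound 4 is therefore 60000 nM, within a range from 25000 nM to 150000 nM, and this assay is expected most likely to report again only a limit for compound 4.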

Compound 4, half-maximal inhibitory concentration: 13700 nM
Compound 4: the middle estimate sits 4.4-fold (0.64 log units) above what was measured; measured number below the stated range.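

Bromo in place of fluoro did not carry over evenly between the two cores in this assay, where the new step is an at least 3.6-fold lower number from compound 3 to compound 4 (0.56 log units; beyond the scatter), and the two steps for this change differ: the same change on two cores in this assay, a 1.2-fold lower number (0.07 log units; within the scatter) from compound 1 to compound 2 and an at least 3.6-fold lower number (0.56 log units; beyond the scatter) from compound 3 to compound 4, at least 3.1-fold (0.49 log units) apart, beyond the scatter of two such steps. The change of bromo in place of chloro, seen here as a 1.3-fold higher number from compound 2 to compound 4 (0.10 log units; within the scatter), likewise depended on which core carried it: the same change on two cores in this assay, an at least 3.9-fold higher number (0.59 log units; beyond the scatter) from compound 1 to compound 3 and a 1.3-fold higher number (0.10 log units; within the scatter) from compound 2 to compound 4, at least 3.1-fold (0.49 log units) apart, beyond the scatter of two such steps. Compound 3 is reported only as a limit, > 50000 nM, so the full size of each step that involves it remains unread, and a single pair of cores shows neither why the steps differ nor how either change would behave on a further core.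

The compounds shown leave open whether the same dependence on the core would appear with a methyl or methoxy group in place of the halogen on either aromatic ring. They also leave open how an amine or a carboxylic acid at those places would read in this assay.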